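This account rests on a few compounds, and the source may have more. Where it says the series, first, only, none or still open, it means among the compounds named here.

Working notes on the series. Compound 2 `Cc1nsc2c1ncn2[C@@H]1O[C@H](CO)[C@@H](O)[C@H]1O` is the reference point here. Among the compounds with values here, in a functional assay on KB cells (Homo sapiens) for antiproliferative activity (a higher number here means a weaker inhibitor, a lower number a stronger inhibitor), compound 2 gives 90000 nM, the only number in the set so far. Compound 1 `CSc1nc2c(C)nsc2n1[C@@H]1O[C@H](CO)[C@@H](O)[C@@H]1O` is the other measured member of the series. In this assay compound 1 gives > 100000 nM, which is a limit of the assay rather than a number; the set thus holds one number and one limit, and the limit of > 100000 nM in this assay, at which 1 of the 2 values shown sits, marks where that limit sits.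

Compound 3 `CSc1nc2c(C)nsc2n1[C@@H]1O[C@H](CO)[C@@H](O)[C@H]1O` is not yet measured. It differs from compound 2 by methylsulfanyl in place of hydrogen on an aromatic carbon, placed on an aromatic carbon of a five-membered aromatic ring with 2 nitrogen, part of a fused or bridged system of two rings, between two ring nitrogen atoms. Within the data shown here, no measured pair shows the effect of such a change, so no size can be read from the data.

With compound 2 already near the edge of the measurable range, the expectation is a step of a 1.1-fold higher number from compound 2 to compound 3 (0.05 log units; within the scatter) in this assay, nothing beyond the scatter. Compound 3 is accordingly estimated at 100000 nM, within 40000 nM to 300000 nM, with a fair chance that only a limit is reported.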

Compound 3, half-maximal inhibitory concentration: > 100000 nM
Compound 3: only a limit was reported (the forecaster's own chance of this, stated with the estimate: 55%); the middle value sits exactly at the limit.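

In this assay compound 3 gives > 100000 nM, which is a limit of the assay and not a number. Within the data shown here, this gives the first reading for methylsulfanyl in place of hydrogen on this aromatic carbon between two ring nitrogen atoms: an at least 1.1-fold higher number from compound 2 to compound 3 (0.04 log units; that floor lies within the scatter), a floor rather than a size, and nothing in it points to a lower number with methylsulfanyl at this position. The step between the two methylsulfanyl compounds, which differ at one saturated ring carbon, cannot be read, because both values are limits: the limit of > 100000 nM in this assay, at which 2 of the 3 values shown sit.

Going by these compounds, how large the methylsulfanyl step truly is stays open, as does any effect of the configuration at that ring carbon in this assay. Also open, on these data alone, is how an amine or a longer chain on the same aromatic carbon would read, and whether any group at this position gives a lower number than compound 2 at 90000 nM.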